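Dichlorophenyl to Dimethylphenyl in a Small Series

The source may report more compounds than this note shows. Statements on the series, on what has been measured and on what is new or still open speak of the compounds shown alone.

In a functional assay (a higher number here means a weaker inhibitor, a lower number a stronger inhibitor), compound 2 `CC(C)=CCOc1ccc2c(c1)OC(c1ccc(Cl)cc1Cl)CC2=O` gives 5260 nM and sits within the scatter of its two measured relatives. Compound 1 `CC(C)=CCOc1ccc2c(c1)OC(c1cccc(F)c1)CC2=O` gives 4280 nM and compound 3 `COc1ccc(C2CC(=O)c3ccc(OCC=C(C)C)cc3O2)cc1` gives 10200 nM on the same scale. Compound 4 `CC(C)=CCOc1ccc2c(c1)OC(c1ccc(C)cc1C)CC2=O` carries 2,4-dimethylphenyl in place of 2,4-dichlorophenyl on a saturated ring carbon and has not yet been measured. Earlier swaps on that carbon stayed small: a 1.2-fold higher number from compound 1 to compound 2 (0.09 log units; within the scatter) and a 1.9-fold higher number from compound 2 to compound 3 (0.29 log units; within the scatter) lie within the scatter, while a 2.4-fold higher number from compound 1 to compound 3 (0.38 log units; beyond the scatter) is only modest. None of them brings in 2,4-dimethylphenyl. The expected change is a 1.1-fold higher number from compound 2 to compound 4 (0.06 log units; within the scatter) in this assay with no shift beyond the scatter expected in either direction. For compound 4 the estimated value is 6000 nM (expected range 2800 nM to 13000 nM).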

Compound 4, half-maximal inhibitory concentration: 8260 nM
For compound 4 the middle estimate is 1.4-fold (0.14 log units) below the measured one; the range from low to high includes it.
By their numbers in this assay, from the lowest: compounds 1, 2, 4 and 3 (each within the scatter of the next, the first and the last beyond it).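

On this saturated ring carbon, 2,4-dimethylphenyl can take the place of 2,4-dichlorophenyl without a shift beyond the scatter in this assay, with a 1.6-fold higher number from compound 2 to compound 4 (0.20 log units; within the scatter). Compound 4 also lies within the scatter of the other two compounds, with a 1.2-fold lower number from compound 3 to compound 4 (0.09 log units; within the scatter) and a 1.9-fold higher number from compound 1 to compound 4 (0.29 log units; within the scatter), so it fits between two compounds that do differ beyond the scatter. No independent measurement bears on why these steps are small. The compounds shown leave open whether an amine or a carboxylic acid on this phenyl ring, in place of methyl or chlorine, would produce a step beyond the scatter.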